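The compounds below may be only part of what the source reports. "The series", "measured", "known", "first", "only" and "open" are said of these compounds alone.

Compound 1 `COC/C1=C/C[C@](C)(CCC=C(C)C)/C=C/[C@@H](OC(=O)C=C(C)C)[C@](C)(O)/C=C/C1=O` gives 3070 nM in a functional assay on HL-60 cells (Homo sapiens) for antiproliferative activity, read by MTT assay, with a stated time of 48 h (on this read-out lower numbers stand for stronger inhibition and higher numbers for weaker inhibition), the lowest of the two numbers shown. Compound 2 `CO[C@]1(C)/C=C/C(=O)/C(CO)=C\C[C@](C)(CCC=C(C)C)/C=C/[C@H]1OC(=O)C=C(C)C` gives 14300 nM in this assay, a higher number that lies beyond the scatter. Compound 3 `CC(C)=CCC[C@]1(C)/C=C/[C@@H](OC(=O)C=C(C)C)[C@](C)(O)CCC(=O)/C(CO)=C\C1` returns only a limit of the assay, > 40000 nM in this assay, so that one of the three values sits at the limit of > 40000 nM in this assay, at which 1 of the 3 values shown sits. Compound 4 `CC(C)=CCC[C@]1(C)/C=C/[C@@H](OC(=O)C=C(C)C)[C@](C)(O)/C=C/C(=O)/C(COC(=O)c2ccc([N+](=O)[O-])cc2)=C\C1` has not yet been measured. It differs from compound 1 in one place: (4-nitrophenyl)carbonyl in place of methyl on an oxygen on a saturated carbon. Going by the values given here, no step between measured compounds carries this change, so its size in this assay is open. A modest move toward a higher number, or none beyond the scatter, is expected. Compound 4 is estimated at 4500 nM, in the range 1200 nM to 18000 nM, which corresponds to a 1.5-fold higher number from compound 1 to compound 4 (0.17 log units; within the scatter).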

Compound 4, half-maximal inhibitory concentration: 830 nM
Beside the measured number, compound 4's estimate is 5.4-fold (0.73 log units) above it; measured number below the stated range.
By their numbers in this assay, from the lowest: compound 4; then compound 1; then compound 2. At a limit, above all of these: compound 3.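

Replacing methyl with (4-nitrophenyl)carbonyl on an oxygen on a saturated carbon gives a 3.7-fold lower number from compound 1 to compound 4 (0.57 log units; beyond the scatter) in this assay. This place on the core of compound 1 therefore accepts a larger group carrying an aromatic ring, and the number falls rather than rises. Nothing measured here accounts for the step. The compounds shown leave open which part of the entering group carries this step: an acetyl or an unsubstituted benzoyl on the same oxygen would separate the carbonyl, the ring and the nitro group.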